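The compounds below may be only part of what the source reports. "The series", "measured", "known", "first", "only" and "open" are said of these compounds alone.

In an in vitro ADME assay on microsomes from liver (Macaca fascicularis) for metabolic stability (a higher number here means faster removal of the compound, a lower number slower removal), the measured compounds read:

- compound 1 `CCC(CC)[C@@H]1C(=O)N[C@H](C2Cc3ccccc3C2)C(=O)N1[C@@H](C(=O)N1CCOCC1)c1ccc(C)nc1` gives 18 mL.min-1.g-1
- compound 2 `Cc1ccc([C@H](C(=O)N(C)C)N2C(=O)[C@@H](C3Cc4ccccc4C3)NC(=O)[C@H]2CC(C)C)cn1` gives 21000 mL.min-1.g-1

Compound 2 stands highest of these two numbers, and its gap to compound 1 lies well beyond the scatter. Compound 3 `CCC(CC)[C@@H]1C(=O)N[C@H](C2Cc3ccccc3C2)C(=O)N1[C@@H](C(=O)N(C)C)c1ccc(C)nc1` has pentan-3-yl in place of isobutyl on a saturated ring carbon. Among the measured compounds shown here, the two measured compounds differ in more than one place, so no measured step isolates this change. A large fall in this assay, beyond the scatter, is expected because compound 1 with the same pentan-3-yl gives 18 mL.min-1.g-1. The expected step is a 140-fold lower number from compound 2 to compound 3 (2.15 log units; beyond the scatter). Compound 3 is estimated at 150 mL.min-1.g-1, within a range of 15 mL.min-1.g-1 to 3000 mL.min-1.g-1.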

Compound 3, intrinsic clearance in microsomes: 12 mL.min-1.g-1
For compound 3 the middle estimate is 13-fold (1.10 log units) above the measured one, and the stated range ends above it.
By their numbers in this assay, from the lowest: compounds 3 and 1 (each within the scatter of the next); then compound 2.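

In this assay, among the compounds shown here, the single swap of isobutyl for pentan-3-yl on the saturated ring carbon gives a 1800-fold lower number from compound 2 to compound 3 (3.24 log units; beyond the scatter) and so accounts for the whole gap at this position. With pentan-3-yl kept in place, dimethylamino in place of morpholin-4-yl on a carbonyl carbon gives a 1.5-fold lower number from compound 1 to compound 3 (0.18 log units; within the scatter) and stays within the scatter. Nothing measured here explains the size of the first step.

On these data alone, how a cyclohexyl group or an ethyl chain on this ring carbon would read remains open. So does whether morpholin-4-yl on the carbonyl carbon would matter as little alongside isobutyl.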